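Amide-substituent variation in a shared-core series

The compounds below may be only part of what the source reports. "The series", "measured", "known", "first", "only" and "open" are said of these compounds alone.

Measured compounds in a functional assay on A549 cells (Homo sapiens) for inhibition, read by MTT assay, with a stated time of 72 h; on this read-out lower numbers stand for stronger inhibition and higher numbers for weaker inhibition:
compound 1 `O=C(CCC(=O)OCCCCCCSc1ccc([N+](=O)[O-])c2nonc12)Nc1ccccc1Cl`: 2750 nM
compound 2 `Cc1ccccc1NC(=O)CCC(=O)OCCCCCCSc1ccc([N+](=O)[O-])c2nonc12`: 4200 nM
compound 3 `COc1ccc(NC(=O)CCC(=O)OCCCCCCSc2ccc([N+](=O)[O-])c3nonc23)cc1`: 6480 nM

Compound 2 sits second highest of the three numbers. Its nearest neighbour is compound 1, with a 1.5-fold higher number from compound 1 to compound 2 (0.18 log units; within the scatter), and its furthest is compound 3, with a 1.5-fold higher number from compound 2 to compound 3 (0.19 log units; within the scatter); both steps lie within the scatter, so compound 2 cannot be set apart from either. Among the measured compounds shown here, the only step beyond the scatter is a 2.4-fold higher number from compound 1 to compound 3 (0.37 log units; beyond the scatter), and that one is modest.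

Compound 4 `CN(C)CCCNC(=O)CCC(=O)OCCCCCCSc1ccc([N+](=O)[O-])c2nonc12` is not yet measured. The change from compound 2 is 3-(dimethylamino)propyl in place of 2-methylphenyl on an amide-type nitrogen. For the measured compounds named here, all three measured steps exchange one substituted phenyl for another on the amide-type nitrogen; none replaces the aryl group by an acyclic chain, so no measured step bears directly on this change. What the measured steps do show is that varying the group on the amide-type nitrogen has moved this assay only by small amounts. On that basis a small shift is expected, direction uncertain, with a wide range to reflect the lack of a precedent: compound 4 is estimated at 6500 nM, between 2500 nM and 18000 nM, which corresponds to an expected 1.5-fold higher number from compound 2 to compound 4 (0.19 log units; within the scatter).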

Compound 4, half-maximal inhibitory concentration: 1580 nM
Beside the measured number, compound 4's estimate is 4.1-fold (0.61 log units) above it, and the stated range ends above it.
By their numbers in this assay, from the lowest: compounds 4, 1, 2 and 3 (each within the scatter of the next, the first and the last beyond it).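

Among the compounds shown here, compound 4 brings the only ring-free group onto the amide-type nitrogen, and in this assay the 3-(dimethylamino)propyl group stands beyond the scatter against two of the aryl amides (a 2.7-fold lower number from compound 2 to compound 4 (0.42 log units; beyond the scatter); a 4.1-fold lower number from compound 3 to compound 4 (0.61 log units; beyond the scatter)), both in the direction of stronger inhibition. The 2-chlorophenyl amide is not set apart from it (a 1.7-fold lower number from compound 1 to compound 4 (0.24 log units; within the scatter)), so compound 4 cannot be called the strongest of the four, but the position clearly accepts an acyclic chain in place of a substituted phenyl without any rise in the number, and the step from the 4-methoxyphenyl group is the largest yet seen at this position, though still modest. No measured evidence here accounts for the lower number of compound 4.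

The compounds shown leave open whether the step follows from losing the aromatic ring or from the dimethylamino nitrogen, a question that a plain butyl chain of carbon only or a 3-morpholinopropyl group would address. From the compounds shown here alone, the effect of chain length also remains open, as a 2-(dimethylamino)ethyl group or a longer 4-(dimethylamino)butyl group would show.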